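This account rests on a few compounds, and the source may have more. Where it says the series, first, only, none or still open, it means among the compounds named here.

Compound 1, with the structure `COC(=O)/C=C1\Nc2cc(-c3ccccc3)ccc2OC1=O`, is the starting point of this account. In an ADME assay on Vero cells (Chlorocebus sabaeus) for cytotoxicity, read by MTT assay, with a stated time of 72 h (a higher number here means that more compound is tolerated, a lower number that less compound is tolerated), compound 1 gives "not determined" (no result reported), so no single number places it among the others. Two related compounds do carry results. Compound 2, the structure `Cc1ccccc1C(=O)/C=C1\Nc2ccccc2OC1=O`, reaches only a limit of the assay: in this assay compound 2 gives > 1790000 nM. Compound 3, built as `O=C(NNC(=O)c1ccncc1)C(=O)Nc1ccccc1O`, gives 1410000 nM in this assay. Within the data shown here, of the three values shown, one sits at the limit of > 1790000 nM in this assay, at which 1 of the 3 values shown sits, and the other two, for compound 2 and compound 3, lie close to one another; no step between them is given, so only the two values themselves can be read.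

Compound 4, drawn as `COC(=O)/C=C1\Nc2cc(Cl)ccc2OC1=O`, follows from compound 1 by one change: chloro in place of phenyl on an aromatic carbon. Among the measured compounds shown here, no measured step of this kind exists among the compounds here, so no direction can be taken from them. Given what compound 2 and compound 3 show, compound 4 is expected to fall in the same well-tolerated region, with any shift from the neighbours staying within the scatter, and compound 4 is estimated at 1000000 nM, between 200000 nM and 2500000 nM.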

Compound 4, half-maximal cytotoxic concentration: 1630000 nM
Compound 4: middle estimate off by 1.6-fold (0.21 log units), on the low side; low and high end bracket the measured number.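

In this assay compound 1 gives "not determined" (no result reported) and compound 4 gives 1630000 nM, so no step can be read between compound 1 and compound 4. The compounds shown leave open whether chloro in place of phenyl on an aromatic carbon changes the value in this assay at all, and in which direction.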